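Amide aryl substituent: amino in place of methyl

The compounds below may be only part of what the source reports. "The series", "measured", "known", "first", "only" and "open" are said of these compounds alone.

Working notes on the series. All three measured compounds share one core and differ only in the group on the amide-type nitrogen. In a functional assay on the whole organism for inhibition, with Rattus norvegicus as the target, read by paw edema, at a dose of 100 mg/kg by the oral route (on this read-out lower numbers stand for less inhibition and higher numbers for more inhibition at the one dose given (going by the name of the read-out)), compound 1 `CCCCNC(=O)c1c(O)c2cccnc2n(-c2ccccc2)c1=O` gives 12.8%. Compound 2 `O=C(Nc1ccccc1)c1c(O)c2cccnc2n(-c2ccccc2)c1=O` gives 4.6%, and compound 3 `Cc1ccc(NC(=O)c2c(O)c3cccnc3n(-c3ccccc3)c2=O)cc1` gives -3.5%. Of the three steps between them, only a number 16.3 percentage points lower from compound 1 to compound 3 (beyond the scatter) lies beyond the scatter; a number 8.2 percentage points lower from compound 1 to compound 2 (within the scatter) and a number 8.1 percentage points lower from compound 2 to compound 3 (within the scatter) stay within it. Compound 3 is thus set apart from compound 1 alone, and not from compound 2.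

Compound 4 `Nc1ccc(NC(=O)c2c(O)c3cccnc3n(-c3ccccc3)c2=O)cc1` is not yet measured. It differs from compound 3 by amino in place of methyl on an aromatic carbon. For the measured compounds named here, only one measured step touches the same aromatic carbon, a number 8.1 percentage points lower from compound 2 to compound 3 (within the scatter), and it was within the scatter; no measured step exchanges methyl for amino, so no direction can be read from the set. In this assay compound 4 is expected at 0%, with a range from -12% to 12%. The estimated step of a number 3.5 percentage points higher from compound 3 to compound 4 (within the scatter) is expected to remain within the scatter.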

Compound 4, a percentage reported as inhibition, in the whole organism at one dose (the size of the read-out at that dose, not a potency): -5.5%
Estimate against measurement, compound 4: 5.5 percentage points above; measured number inside the range.
By their numbers in this assay, from the lowest: compounds 4, 3, 2 and 1 (each within the scatter of the next, the first and the last beyond it).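

In this assay, amino in place of methyl on this aromatic carbon gives (a number 2 percentage points lower from compound 3 to compound 4 (within the scatter)), so the two groups are not told apart at this position. Against hydrogen on the same carbon, amino gives (a number 10.1 percentage points lower from compound 2 to compound 4 (beyond the scatter)), which passes the scatter, whereas methyl gave (a number 8.1 percentage points lower from compound 2 to compound 3 (within the scatter)), which did not. Against butyl on the amide-type nitrogen, 4-aminophenyl gives (a number 18.3 percentage points lower from compound 1 to compound 4 (beyond the scatter)), so compound 4 and compound 3 are both set apart from compound 1, while compound 2 is not.

No measured evidence bears on the reason for these steps. Whether a carboxylic acid or a hydroxyl group on this aromatic carbon, or a longer chain in place of butyl on the amide-type nitrogen, would give a number beyond the scatter of these compounds remains open.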